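From compound 3 to compound 4: a methoxy added

The source may hold more compounds than are shown below. What is called first, only, known or untested is meant among the compounds shown, and "the series" means these compounds.

Values in a functional assay on K562 cells (Homo sapiens) for inhibition (a lower number here means a stronger inhibitor of growth, a higher number a weaker inhibitor of growth), so far
compound 1 `O=C(/C=C/c1cccc(O)c1)c1cccc(-n2cc(-c3ccccc3)[nH]c2=O)c1` gives 3350 nM
compound 2 `O=C(/C=C/c1cccc(O)c1)c1cccc(-n2cc(-c3ccc(Cl)cc3)[nH]c2=O)c1` gives 400 nM
compound 3 `COc1cc(/C=C/C(=O)c2cccc(-n3cc(-c4ccccc4)[nH]c3=O)c2)cc(OC)c1OC` gives 500 nM

Compound 3 lies within the scatter of compound 2, and its value is clearly lower than that of compound 1. Compound 4 `COc1ccc(-c2cn(-c3cccc(C(=O)/C=C/c4cc(OC)c(OC)c(OC)c4)c3)c(=O)[nH]2)cc1` differs from it by methoxy in place of hydrogen on an aromatic carbon, para to a large group methoxy in place of hydrogen on an aromatic carbon and so turns phenyl to 4-methoxyphenyl. Among the measured compounds shown here, only one measured step bears on this: chloro in place of hydrogen on an aromatic carbon gave an 8.4-fold lower number from compound 1 to compound 2 (0.92 log units; beyond the scatter) and that step involves another group, on a different background. A smaller step toward a lower number is therefore expected, perhaps not beyond the scatter. The expected change is a 2.0-fold lower number from compound 3 to compound 4 (0.30 log units; within the scatter) as an estimate only. For compound 4 the estimated value is 250 nM with an expected range from 70 nM to 900 nM in this assay here.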

Compound 4, concentration for 50% growth inhibition: 1270 nM
Compound 4: middle estimate off by 5.1-fold (0.71 log units), on the low side; the whole stated range lies below it.
By their numbers in this assay, from the lowest: compounds 2 and 3 (each within the scatter of the next); then compound 4; then compound 1.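

Methoxy on the phenyl group of compound 3, para to a large group, gave a 2.5-fold higher number from compound 3 to compound 4 (0.40 log units; beyond the scatter) in this assay. This step runs opposite to the chloro step, an 8.4-fold lower number from compound 1 to compound 2 (0.92 log units; beyond the scatter), so on these two backgrounds a group added to the phenyl does not move the number in one fixed direction. Nothing shown gives a reason for this difference.

The compounds shown leave open whether chloro would lower the number on the background of compound 3. They also leave open how an amine or a carboxylic acid would read in this place.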